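Replacing the carboxy group of compound 2 with 2-aminobenzyl

The compounds below may be only part of what the source reports. "The series", "measured", "known", "first", "only" and "open" are said of these compounds alone.

In a functional assay on P388 cells (Mus musculus) for cytotoxicity (on this read-out lower numbers stand for stronger inhibition and higher numbers for weaker inhibition), compound 1 (`Cc1cc(-c2c(F)cc3c(=O)c(Cc4ccccc4O)cn(C4CC4)c3c2F)cc(C)n1`), which carries a 2-hydroxybenzyl group, gives 670 nM. Compound 2 (`Cc1cc(-c2c(F)cc3c(=O)c(C(=O)O)cn(C4CC4)c3c2F)cc(C)n1`), which carries a carboxy group instead, gives 29000 nM, the higher of the two numbers. Compound 3 (`Cc1cc(-c2c(F)cc3c(=O)c(Cc4ccccc4N)cn(C4CC4)c3c2F)cc(C)n1`) has not yet been measured. It puts 2-aminobenzyl in place of carboxy on an aromatic carbon of compound 2: 2-aminobenzyl in place of carboxy on an aromatic carbon. Among the compounds with values here, only one measured step bears on this change: a 43-fold higher number from compound 1 to compound 2 (1.64 log units; beyond the scatter), with carboxy replacing 2-hydroxybenzyl. Within the data shown here, the new change runs the opposite way, but a different benzyl group enters, and no measurement yet compares the two benzyl groups. A large step towards a lower number in this assay is therefore expected, of similar size. The expected step is a 45-fold lower number from compound 2 to compound 3 (1.65 log units; beyond the scatter). Compound 3 is estimated at 650 nM, with a range of 170 nM to 2500 nM.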

Compound 3, half-maximal inhibitory concentration: 2100 nM
For compound 3 the middle estimate is 3.2-fold (0.51 log units) below the measured one; low and high end bracket the measured number.
By their numbers in this assay, from the lowest: compound 1; then compound 3; then compound 2.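

In this assay, the gain over carboxy at this position does not depend on the hydroxy group, as 2-aminobenzyl also brings a large change, with a 14-fold lower number from compound 2 to compound 3 (1.14 log units; beyond the scatter) in this read-out. The two benzyl groups are nevertheless not equivalent: amino in place of hydroxy gives a 3.1-fold higher number from compound 1 to compound 3 (0.50 log units; beyond the scatter) in the same assay, a modest step that still lies beyond the scatter. The data offer no evidence on what lies behind either step.

As far as these compounds go, what the ring itself contributes, apart from its amino or hydroxy group, remains open, and plain benzyl would speak to that. A 2-methoxybenzyl group or a 3-hydroxybenzyl group at the same carbon would show whether the order of the two benzyl groups extends beyond this pair.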